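This account rests on a few compounds, and the source may have more. Where it says the series, first, only, none or still open, it means among the compounds named here.

Compound 1, `Cc1ccc(S(=O)(=O)N(Nc2ccccc2)C(=O)Oc2ccccc2)cc1`: 5720 nM
Compound 2, `Cc1ccc(OC(=O)N(Nc2ccccc2)S(=O)(=O)c2ccc(C)cc2)cc1`: 1010 nM

Both numbers come from a functional assay on RAW264.7 cells (Mus musculus), read by immunoassay, with a stated time of 24 h; a higher number here means a weaker inhibitor, a lower number a stronger inhibitor. Compound 1 stands highest of the two; its nearest neighbour is compound 2, and the move a 5.7-fold lower number from compound 1 to compound 2 (0.75 log units; beyond the scatter) is a modest step, beyond the usual scatter, that comes with a methyl in place of hydrogen on an aromatic carbon. Compound 3, `COc1ccc(S(=O)(=O)N(Nc2ccccc2)C(=O)Oc2ccccc2)cc1`, has not yet been measured in this assay. It differs from compound 1 by methoxy in place of methyl on an aromatic carbon. For the measured compounds named here, no measured pair here shows a methoxy in place of methyl on an aromatic carbon; the only measured step, from compound 1 to compound 2, is a different change at a different place, so it gives no direct guide to the size or direction of the present one. Going by the values given here, with no comparable step to lean on, the expectation for compound 3 is a change no larger than the scatter, in either direction, expressed as a 1.0-fold lower number from compound 1 to compound 3 (0.02 log units; within the scatter). The estimate for compound 3 is therefore 5500 nM, with an expected range from 2000 nM to 15000 nM.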

Compound 3, half-maximal inhibitory concentration: 4430 nM
Compound 3: middle estimate off by 1.2-fold (0.09 log units), on the high side; the measured number falls inside the stated range.
By their numbers in this assay, from the lowest: compound 2; then compounds 3 and 1 (each within the scatter of the next).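

Replacing methyl with methoxy on the aromatic carbon para to a large group gives a 1.3-fold lower number from compound 1 to compound 3 (0.11 log units; within the scatter) in this assay. This position therefore takes a group with one more heavy atom and an added hydrogen-bond acceptor without a change that can be told apart from ordinary repeat-to-repeat variation, at least for this pair, whereas the earlier step, a 5.7-fold lower number from compound 1 to compound 2 (0.75 log units; beyond the scatter), added a methyl at a different place in the molecule and did go beyond the scatter. No independent measurement bears on this result, so the small step stands as an observation without an explanation.

Going by these compounds, two groups say little about the full range this position will accept, so it remains open whether an amine, a carboxylic acid, a chlorine atom or a longer chain such as ethoxy on the same carbon would leave the number as flat or shift it clearly. On these data alone, it is also open whether methoxy would behave the same way at the place where the added methyl of compound 2 produced a step beyond the scatter.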